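Swapping the amine at the end of the chain

The source may hold more compounds than are shown below. What is called first, only, known or untested is meant among the compounds shown, and "the series" means these compounds.

Compound 2 `COc1cc2c(Nc3ccc(C#N)cc3)ncnc2cc1OCCCN1CCC(c2ccccc2)CC1` gives the lower of the two measured numbers in a functional assay on DU-145 cells (Homo sapiens) for antiproliferative activity, read by MTT assay, with a stated time of 72 h; a higher number here means a weaker inhibitor, a lower number a stronger inhibitor: compound 2 gives 6790 nM, while compound 1 `CCN(CC)CCCOc1cc2ncnc(Nc3ccc(C#N)cc3)c2cc1OC` gives 68900 nM. Going by the values given here, the only measured step is a 10-fold lower number from compound 1 to compound 2 (1.01 log units; beyond the scatter), which shows that the amine at the end of the chain can move the result a long way. Among the compounds with values here, compound 3 `COc1cc2c(Nc3ccc(C#N)cc3)ncnc2cc1OCCCN1CCc2ccccc2C1` keeps everything else and changes only this group: 1,2,3,4-tetrahydroisoquinolin-2-yl in place of 4-phenylpiperidin-1-yl on a saturated chain carbon, three bonds along the chain from an oxygen on an aromatic ring. Within the data shown here, the group that enters, like the one that leaves, pairs a saturated six-membered ring holding the nitrogen with an aromatic ring of carbon only, so the change is far smaller in kind than the one between compound 1 and compound 2. No measured step tests this particular swap, so the expectation rests on the single step shown and on what the two groups share. Compound 3 is therefore expected to land close to compound 2. The expected step is modest, a 1.5-fold higher number from compound 2 to compound 3 (0.17 log units; within the scatter), likely within the scatter or a little above it. The estimate for compound 3 in this assay is 10000 nM, within the range 3500 nM to 30000 nM.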

Compound 3, half-maximal inhibitory concentration: > 100000 nM
Compound 3: no number, only a limit; the forecaster's own chance of this, stated with the estimate: 5%; middle value at least 10-fold (1.00 log units) from the limit.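

In this assay compound 3 gives a limit and not a number: the limit of > 100000 nM in this assay, at which 1 of the 3 values shown sits. Even so, the change reads as an at least 14-fold higher number from compound 2 to compound 3 (1.16 log units; beyond the scatter), so two groups with the same kinds of ring, a saturated six-membered ring holding the nitrogen and an aromatic ring of carbon only, are not interchangeable on a saturated chain carbon, three bonds along the chain from an oxygen on an aromatic ring. Against the diethylamino group of the first compound, the change reads as an at least 1.4-fold higher number from compound 1 to compound 3 (0.16 log units; that floor lies within the scatter), so having an aromatic ring in the amine group is not enough to bring the lower number seen with 4-phenylpiperidin-1-yl, and the order of compound 1 and compound 3 stays unsettled.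

The compounds shown leave open whether the phenyl ring of compound 2 matters at all, a question that a plain piperidin-1-yl group on the same chain would address. On these data alone, whether 4-phenylpiperidin-1-yl would keep its lead over 1,2,3,4-tetrahydroisoquinolin-2-yl on a longer chain also remains open.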